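This account rests on a few compounds, and the source may have more. Where it says the series, first, only, none or still open, it means among the compounds named here.

Measured compounds:
Compound 1, `O=c1n(Cc2nc(-c3ncccn3)cn2CCCCO)c2cnccc2n1C1CC1` — in an ADME assay on microsomes from liver (Homo sapiens) for metabolic stability (on this read-out lower numbers stand for slow clearance and higher numbers for fast clearance), compound 1 gives < 8 mL.min-1.g-1, which is a limit of the assay.
Compound 2, `O=c1n(Cc2nc(-c3ccccn3)cn2CCCCO)c2cnccc2n1C1CC1` — in this assay compound 2 gives < 8 mL.min-1.g-1, which is likewise a limit of the assay.

Compound 2 therefore stands at the limit of this assay, and no number is known for it. The same holds for every value shown, as the limit of < 8 mL.min-1.g-1 in this assay, at which 2 of the 2 values shown sit, records. Within the data shown here, the only measured step, a step that the two limits leave unreadable from compound 1 to compound 2, cannot be sized, since both of its ends sit at the limit recorded in the limit of < 8 mL.min-1.g-1 in this assay, at which 2 of the 2 values shown sit. Among the measured compounds shown here, nothing measured so far tells how large a change of the aryl group at that position can be in this assay.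

Compound 3, `Cc1nnc(-c2cn(CCCCO)c(Cn3c(=O)n(C4CC4)c4ccncc43)n2)s1`, differs from compound 2 in one place: 5-methyl-1,3,4-thiadiazol-2-yl in place of pyridin-2-yl on an aromatic carbon. For the measured compounds named here, no measured step involves a five-membered ring of this kind, so the change has no measured counterpart. With both known values at the limit, the expected step is a step that the limit leaves unreadable from compound 2 to compound 3, not beyond the scatter. Compound 3 is accordingly estimated at 6 mL.min-1.g-1 in this assay, with a range from 3 mL.min-1.g-1 to 14 mL.min-1.g-1.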

Compound 3, intrinsic clearance in microsomes: < 8 mL.min-1.g-1
Compound 3: a limit, no number; the forecaster's own chance of this, stated with the estimate: 65%; the middle value does not contradict the limit.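

In this assay compound 3 gives < 8 mL.min-1.g-1 as a limit of the assay, not a number. Among these compounds, no step among compound 1, compound 2 and compound 3 can be read, because all three sit at the same limit: the limit of < 8 mL.min-1.g-1 in this assay, at which 3 of the 3 values shown sit. The compounds shown leave open how far clearance differs among these three aryl groups, and whether any change at that position would bring a value off the limit.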